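The source may hold more compounds than are shown below. What is called first, only, known or untested is meant among the compounds shown, and "the series" means these compounds.

- compound 1 `CC#CCn1c(N2CCC[C@@H](N)C2)cc(=O)n(Cc2ccc(Cl)c(C(=O)O)c2)c1=O` at 8270 ng.h/mL
- compound 2 `CC#CCn1c(N2CCC[C@@H](N)C2)cc(=O)n(Cc2ccc(F)c(C(=O)OC)c2)c1=O` at 1740 ng.h/mL

Both values come from an ADME assay on the whole organism (Rattus norvegicus, strain Sprague-Dawley) for pharmacokinetics, read by LC-MS, with a stated time of 48 h, at a dose of 3 mg/kg by the intravenous route (a higher number here means more compound in the circulation at the dose given, a lower number less compound in the circulation), and compound 2 stands lowest of the two, with its gap to compound 1 beyond the usual scatter. Compound 3 `CC#CCn1c(N2CCC[C@@H](N)C2)cc(=O)n(Cc2ccc(F)c(C(=O)O)c2)c1=O` differs from compound 2 by hydrogen in place of methyl on an oxygen next to a carbonyl group with hydrogen in place of methyl on an oxygen next to a carbonyl group, methoxycarbonyl to carboxy. Among the compounds with values here, no measured pair shows this change alone. Compound 2 differs from compound 1 in more than one place, but compound 1 carries carboxy and gives 8270 ng.h/mL and so a rise beyond the scatter is expected. The estimated step is a 3.7-fold higher number from compound 2 to compound 3 (0.57 log units; beyond the scatter) in this assay on this reading. For compound 3 the expected value is 6500 ng.h/mL with 2800 ng.h/mL to 14000 ng.h/mL as its estimated range.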

Compound 3, area under the concentration-time curve: 5360 ng.h/mL
Estimate against measurement, compound 3: 1.2-fold (0.08 log units) above; the range from low to high includes it.
By their numbers in this assay, from the lowest: compound 2; then compounds 3 and 1 (each within the scatter of the next).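

In this assay, hydrogen in place of methyl on an oxygen next to a carbonyl group now stands as a clean single change on the fluoro compounds (a 3.1-fold higher number from compound 2 to compound 3 (0.49 log units; beyond the scatter)), so carboxy carries more compound in the circulation than methoxycarbonyl here. With carboxy held, fluoro in place of chloro on an aromatic carbon gives a step within the scatter (a 1.5-fold lower number from compound 1 to compound 3 (0.19 log units; within the scatter)). Nothing measured here accounts for either step. The compounds shown leave open whether a primary amide or a tetrazole in place of carboxy would keep this level, and whether bromo in place of the halogen would.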